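Hydroxyphenyl replacing benzodioxinyl-carbonyl on the piperazine of compound 3

The compounds below may be only part of what the source reports. "The series", "measured", "known", "first", "only" and "open" are said of these compounds alone.

Working notes on a series built on one shared core, read in a functional assay on HT-29 cells (Homo sapiens) for inhibition, read by sulforhodamine B assay; on this read-out higher numbers stand for weaker inhibition and lower numbers for stronger inhibition. Compound 1 `COC(=O)CC/C(C)=C/Cc1c(OC)c(C)c2c(c1OCC#CCN1CCN(c3ccc(C)cc3)CC1)C(=O)OC2`, compound 2 `COC(=O)CC/C(C)=C/Cc1c(OC)c(C)c2c(c1OCC#CCN1CCN(c3ccc(C#N)cc3)CC1)C(=O)OC2` and compound 3 `COC(=O)CC/C(C)=C/Cc1c(OC)c(C)c2c(c1OCC#CCN1CCN(C(=O)C3COc4ccccc4O3)CC1)C(=O)OC2` have been measured. Compound 1 gives only a limit in this assay, > 50000 nM. Compound 2 likewise gives only a limit, > 50000 nM. Compound 3 too reaches only a limit, > 50000 nM, so compound 3 stands where every value in the series stands so far: at the limit of > 50000 nM in this assay, at which 3 of the 3 values shown sit. None of the steps among these three is readable: a step that the two limits leave unreadable from compound 1 to compound 2, a step that the two limits leave unreadable from compound 1 to compound 3 and a step that the two limits leave unreadable from compound 2 to compound 3.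

Compound 4 `COC(=O)CC/C(C)=C/Cc1c(OC)c(C)c2c(c1OCC#CCN1CCN(c3ccc(O)cc3)CC1)C(=O)OC2` is the next candidate. It differs from compound 3 by 4-hydroxyphenyl in place of (2,3-dihydro-1,4-benzodioxin-2-yl)carbonyl on an amine nitrogen in a ring. Among the compounds with values here, no measured step speaks to a change at the amine nitrogen in a ring in a readable way, since all steps that alter that position end at the same limit. Within the data shown here, the only evidence is that three variations on this nitrogen, including two aryl groups and one carbonyl-linked group, leave the read-out at the limit.

The expected step is a step that the limit leaves unreadable from compound 3 to compound 4, which is none beyond the scatter as far as a limit can be compared. Compound 4 is therefore estimated at 70000 nM, with a range of 20000 nM to 250000 nM, and most likely again only a limit in this assay.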

Compound 4, half-maximal inhibitory concentration: > 50000 nM
Compound 4: a limit, no number (the forecaster's own chance of this, stated with the estimate: 85%); the middle value does not contradict the limit.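

In this assay compound 4 gives > 50000 nM as a limit and not a number, so none of the steps to compound 4 from compound 1, compound 2 or compound 3 can be read. The compounds shown leave open whether any group on the amine nitrogen in a ring gives a number rather than a limit, and the series so far stands at a single place: the limit of > 50000 nM in this assay, at which 4 of the 4 values shown sit.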